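The source may hold more compounds than are shown below. What is called first, only, known or untested is meant among the compounds shown, and "the series" means these compounds.

In a functional assay on THP-1 cells (Homo sapiens), read by colorimetric assay, with a stated time of 1 h (a higher number here means that more compound is needed for the effect, a lower number that less compound is needed), compound 1 `C=C(C(=O)OCC)C(OCCC(=O)OCC)c1ccc(Cl)cc1Cl` gives 79.4 nM and compound 2 `C/C=C(/C(=O)OCC)C(O)c1ccccc1Cl` gives 126 nM as its reading. These two values lie within the scatter of each other, so compound 2 stands level with compound 1 and neither can be ranked above the other. Compound 3 `C/C=C(\C(=O)OCC)C(O)c1ccccc1Cl` has not yet been measured. Its difference from compound 2 is the two compounds have the same atoms and bonds; at least one stereo element is drawn with a configuration in one of them and without one in the other: 1 of 2 stereo elements differ; a double bond is drawn E in compound 2 and Z in compound 3 and amounts to a single stereo element: the two compounds have the same atoms and bonds, and a double bond is drawn E in compound 2 and Z in compound 3. Within the data shown here, no pair of double-bond isomers has been measured yet, so the data give no direct guide to this change. With compound 2 at 126 nM as the closest reference, no step beyond the scatter is expected in this assay and no firm direction can be given, although a larger step cannot be ruled out. The expected change is a 1.2-fold higher number from compound 2 to compound 3 (0.08 log units; within the scatter) in size. Compound 3 is expected at 150 nM with 45 nM to 500 nM as the estimated range.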

Compound 3, half-maximal effective concentration: 100 nM
Beside the measured number, compound 3's estimate is 1.5-fold (0.18 log units) above it, within the range that was stated.
By their numbers in this assay, from the lowest: compounds 1, 3 and 2 (each within the scatter of the next).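

Among these compounds, compound 2 and compound 3 form the first pair here that differs in only one place, so the double bond can now be examined on its own, which compound 1 and compound 2 did not allow. In this assay, going from the E to the Z double bond gives a 1.3-fold lower number from compound 2 to compound 3 (0.10 log units; within the scatter), so this change at this position does not separate the two compounds beyond the scatter, and neither can be ranked above the other. The comparison carries one qualification, which stands in the drawn structures themselves: the fact that one of compounds 2 and 3 is drawn with a defined configuration and the other without, at the place where they differ

The compounds shown leave open whether the double-bond geometry would count for as little with a carboxylic acid in place of the ethyl ester, or with an amine in place of the hydroxyl group. On these data alone, they also give no reading on the second stereo element, which does not differ between compound 2 and compound 3, so its contribution in this assay remains unknown.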